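Swapping Halogenated Phenyl Groups on a Weak Growth Inhibitor

This account rests on a few compounds, and the source may have more. Where it says the series, first, only, none or still open, it means among the compounds named here.

Compound 1, `N#Cc1ccc(Nc2nc(Oc3ccnc4ccccc34)nc(N3CCN(c4ccccc4Cl)CC3)n2)cc1C(F)(F)F`, was tested in a functional assay on DU-145 cells (Homo sapiens) for cytotoxicity, read by sulforhodamine B assay, with a stated time of 48 h (a lower number here means a stronger inhibitor of growth, a higher number a weaker inhibitor of growth), where compound 1 gives 92600 nM. Among the two plain numbers shown it is the highest, and its nearest neighbour is compound 3, `CCN1CCN(c2nc(Nc3ccc(C#N)c(C(F)(F)F)c3)nc(Oc3ccnc4ccccc34)n2)CC1`, which in this assay gives 86600 nM. Compound 2, `N#Cc1ccc(Nc2nc(Oc3ccnc4ccccc34)nc(N3CCN(c4ccccc4F)CC3)n2)cc1C(F)(F)F`, reaches only the limit of this assay, where compound 2 gives > 100000 nM; this is a limit, not a measured number. The step of an at least 1.0-fold higher number from compound 1 to compound 2 (0.03 log units; that floor lies within the scatter) and the step of a 1.1-fold lower number from compound 1 to compound 3 (0.03 log units; within the scatter) both stay within the scatter, as does an at least 1.1-fold lower number from compound 2 to compound 3 (0.06 log units; that floor lies within the scatter), and the limit of > 100000 nM in this assay, at which 1 of the 3 values shown sits, is reached by one of the three compounds.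

Compound 4, `N#Cc1ccc(Nc2nc(Oc3ccnc4ccccc34)nc(N3CCN(c4ccc(F)cc4)CC3)n2)cc1C(F)(F)F`, differs from compound 1 in one place: 4-fluorophenyl in place of 2-chlorophenyl on an amine nitrogen in a ring. The measured steps that bear on this change are the halogen exchange on the same aromatic ring and the replacement of the whole aryl group by ethyl, and neither of them moved the number beyond the scatter. The expected step is therefore small, a 1.1-fold higher number from compound 1 to compound 4 (0.03 log units; within the scatter), with no clear direction. The estimated value for compound 4 in this assay is 100000 nM, within an expected range from 40000 nM to 250000 nM.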

Compound 4, concentration for 50% growth inhibition: > 100000 nM
Compound 4: only a limit was reported; the forecaster's own chance of this, stated with the estimate: 50%; the middle value sits exactly at the limit.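

The new change alters both the halogen and its place on the phenyl ring at once, yet in this assay it gives an at least 1.0-fold higher number from compound 1 to compound 4 (0.03 log units; that floor lies within the scatter), so this double swap on the amine nitrogen in a ring shows no gain in growth inhibition. Among these compounds, replacing ethyl on the same nitrogen with 4-fluorophenyl gives an at least 1.1-fold higher number from compound 3 to compound 4 (0.06 log units; that floor lies within the scatter), which means that ethyl and three different halogenated phenyl groups have now been seen at this position, and no step that can be read lies beyond the scatter. The step between the 2-fluorophenyl and 4-fluorophenyl compounds cannot be read, so moving the fluorine around the ring can be judged neither way, since compound 2 and compound 4 each gave only a limit rather than a number: the limit of > 100000 nM in this assay, at which 2 of the 4 values shown sit.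

Still open, going by these compounds, is whether an unsubstituted phenyl, a 4-methoxyphenyl, or a longer chain ending in an amine or a carboxylic acid on this nitrogen would move the number beyond the scatter. Also open, on these data alone, is how far compound 2 and compound 4 truly lie past their limit, and whether changes elsewhere on the shared core would matter more in this assay.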